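Hydrazone series: carboxymethyl in place of cyclopropyl

The compounds below may be only part of what the source reports. "The series", "measured", "known", "first", "only" and "open" are said of these compounds alone.

Measured so far:
Compound 1, `CC1CC/C(=N\Nc2ccc(F)cc2)c2ncc(C(=O)O)c(=O)n21`, gives 12.2 umol/kg in a functional assay on the whole organism for inhibition, with Rattus norvegicus as the target; a lower number here means that less compound is needed, a higher number that more compound is needed for the effect.
Compound 2, `CC1CC/C(=N\Nc2ccc(O)cc2)c2ncc(C(=O)O)c(=O)n21`, gives 1.7 umol/kg in this assay.
Compound 3, `CC1CC/C(=N\Nc2ccc(C3CC3)cc2)c2ncc(C(=O)O)c(=O)n21`, gives 41.1 umol/kg in this assay.

Compound 3 stands highest of the three numbers: a 3.4-fold higher number from compound 1 to compound 3 (0.53 log units; beyond the scatter), and a 24-fold higher number from compound 2 to compound 3 (1.38 log units; beyond the scatter). Compound 4, `CC1CC/C(=N\Nc2ccc(CC(=O)O)cc2)c2ncc(C(=O)O)c(=O)n21`, differs from compound 3 in one place: carboxymethyl in place of cyclopropyl on an aromatic carbon. Among the measured compounds shown here, the step that bears most directly is a 24-fold higher number from compound 2 to compound 3 (1.38 log units; beyond the scatter), in which the only other group with a hydrogen-bond donor and acceptor at this position stood far lower; a 3.4-fold higher number from compound 1 to compound 3 (0.53 log units; beyond the scatter) points the same way. For the measured compounds named here, a return to a lower number is therefore expected, a 6.9-fold lower number from compound 3 to compound 4 (0.84 log units; beyond the scatter), though the new group is larger than hydroxy and no measured step matches it. Compound 4 is estimated at 6 umol/kg, range 1.5 umol/kg to 25 umol/kg.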

Compound 4, dose for 50% inhibition: 60.9 umol/kg
For compound 4 the middle estimate is 10-fold (1.01 log units) below the measured one; the measured number lies above the stated range.
By their numbers in this assay, from the lowest: compound 2; then compound 1; then compounds 3 and 4 (each within the scatter of the next).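

In this assay, a hydrogen-bond donor and acceptor on this aromatic carbon do not by themselves bring the number down: carboxymethyl does not separate from cyclopropyl (a 1.5-fold higher number from compound 3 to compound 4 (0.17 log units; within the scatter)). Hydroxy stays well apart from carboxymethyl (a 36-fold higher number from compound 2 to compound 4 (1.55 log units; beyond the scatter)), and fluoro also stands apart from it (a 5.0-fold higher number from compound 1 to compound 4 (0.70 log units; beyond the scatter)). Among these four compounds, the low number of compound 2 therefore follows hydroxy itself and not the donor and acceptor counts alone.

No measurement shown accounts for these differences. Open, from the compounds shown here alone, is whether an amine or a methoxy group here would stand with hydroxy, and whether a carboxylic acid on a longer chain would separate from carboxymethyl.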